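Swapping a tetrazole for a thiadiazole in a cytotoxicity series

This account rests on a few compounds, and the source may have more. Where it says the series, first, only, none or still open, it means among the compounds named here.

Of the compounds shown here, two have been measured. In an ADME assay on NIH3T3 cells (Mus musculus) for cytotoxicity, read by MTT assay, with a stated time of 24 h (a lower number here means a stronger inhibitor, a higher number a weaker inhibitor), compound 1 `Cc1nnc(SCC(=O)N/N=c2/scc(-c3ccc(F)cc3)n2-c2ccccc2)s1` gives 383 ug/mL, while compound 2 `COc1ccc(-c2cs/c(=N/NC(=O)CSc3nnnn3-c3ccccc3)n2-c2ccccc2)cc1` gives 11.7 ug/mL. Compound 2 therefore holds the lower of the two numbers, and the gap to compound 1 lies well beyond the scatter; the two compounds differ in more than one place, so the numbers alone do not say which change carries that gap. Compound 3 `COc1ccc(-c2cs/c(=N/NC(=O)CSc3nnc(C)s3)n2-c2ccccc2)cc1` is not yet measured in this assay. For the measured compounds named here, it differs from compound 2 by 5-methyl-1,3,4-thiadiazol-2-yl in place of 1-phenyl-1H-tetrazol-5-yl on a sulfur, and the group that enters is the one found in compound 1. Because compound 1 shows 383 ug/mL with that same group, compound 3 is expected to move toward a higher number, by a step of an 8.5-fold higher number from compound 2 to compound 3 (0.93 log units; beyond the scatter). The estimate for compound 3 is 100 ug/mL, with a likely range from 25 ug/mL to 400 ug/mL.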

Compound 3, half-maximal inhibitory concentration: 300 ug/mL
Estimate against measurement, compound 3: 3.0-fold (0.48 log units) below; the range from low to high includes it.
By their numbers in this assay, from the lowest: compound 2; then compounds 3 and 1 (each within the scatter of the next).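

In this assay the exchange of 1-phenyl-1H-tetrazol-5-yl for 5-methyl-1,3,4-thiadiazol-2-yl on a sulfur gives a 26-fold higher number from compound 2 to compound 3 (1.41 log units; beyond the scatter) and so shows that this one place, on an otherwise unchanged structure, can carry a large step. With 5-methyl-1,3,4-thiadiazol-2-yl held on the sulfur, methoxy in place of fluoro on an aromatic carbon gives a 1.3-fold lower number from compound 1 to compound 3 (0.11 log units; within the scatter) and so makes no difference beyond the scatter in this pair. No measurement here offers an explanation for the step at the sulfur.

The compounds shown leave open whether that step follows the phenyl group or the five-membered ring, as the two groups differ in both. A 1-methyl-1H-tetrazol-5-yl group on the same sulfur would begin to separate these two parts.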